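Fluoro for bromo on the aryl-piperazine of a xanthine sulfonamide

The source may hold more compounds than are shown below. What is called first, only, known or untested is meant among the compounds shown, and "the series" means these compounds.

Compound 1 `CCCn1c(=O)[nH]c2nc(-c3ccc(S(=O)(=O)N4CCN(c5ccc(Cl)cc5F)CC4)cc3)[nH]c2c1=O` gives 1.91 nM in an assay on CHO cells for displacement of a labelled ligand from adenosine receptor A2b (Homo sapiens), read by scintillation counting, with a stated time of 75 min, in the presence of a further agent that is not named here; a higher number here means a weaker inhibitor, a lower number a stronger inhibitor.
Compound 2 `CCCn1c(=O)[nH]c2nc(-c3ccc(S(=O)(=O)N4CCN(c5ccccc5C)CC4)cc3)[nH]c2c1=O` gives 0.432 nM in this assay.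
Compound 3 `CCCn1c(=O)[nH]c2nc(-c3ccc(S(=O)(=O)N4CCN(c5ccccc5Br)CC4)cc3)[nH]c2c1=O` gives 0.137 nM in this assay.

Compound 3 stands lowest of the three: the step of a 3.2-fold lower number from compound 2 to compound 3 (0.50 log units; beyond the scatter) and the step of a 14-fold lower number from compound 1 to compound 3 (1.14 log units; beyond the scatter) both lie beyond the scatter, so compound 3 is the strongest inhibitor among the measured compounds. Compound 4 `CCCn1c(=O)[nH]c2nc(-c3ccc(S(=O)(=O)N4CCN(c5ccccc5F)CC4)cc3)[nH]c2c1=O` differs from compound 3 by a single change, (fluoro in place of bromo on an aromatic carbon), in words fluoro in place of bromo on an aromatic carbon, ortho to the large group. For the measured compounds named here, no measured pair shows exactly this swap. The nearest evidence is the step of a 3.2-fold lower number from compound 2 to compound 3 (0.50 log units; beyond the scatter), where bromo in place of methyl at the same carbon lowered the number, and compound 1, which carries fluoro at that carbon together with chloro elsewhere, gives the highest number of the three. Compound 4 is therefore expected to show a higher number than compound 3, a step of about a 4.4-fold higher number from compound 3 to compound 4 (0.64 log units; beyond the scatter) in this assay. The estimated value of compound 4 is 0.6 nM, within a range of 0.2 nM to 2 nM.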

Compound 4, inhibition constant: 3.22 nM
Compound 4: the middle estimate sits 5.4-fold (0.73 log units) below what was measured; measured number outside the range, above it.
By their numbers in this assay, from the lowest: compound 3; then compound 2; then compounds 1 and 4 (each within the scatter of the next).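

At this carbon, ortho to a large group, the choice of substituent weighs heavily in this assay: the step of a 24-fold higher number from compound 3 to compound 4 (1.37 log units; beyond the scatter) is large, and the step of a 7.5-fold higher number from compound 2 to compound 4 (0.87 log units; beyond the scatter) places fluoro behind methyl as well, so bromo, methyl and fluoro now form a clear order at one position. The step of a 1.7-fold higher number from compound 1 to compound 4 (0.23 log units; within the scatter) lies within the scatter, so hydrogen in place of chloro makes no readable difference when fluoro occupies this carbon, and the high number of compound 1 no longer needs the chloro to account for it. Nothing measured on these compounds explains the size of the fluoro and bromo gap.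

The compounds shown leave open how chloro, iodo or methoxy at this carbon would rank against bromo. They also leave open whether a chloro elsewhere on the ring would remain without readable effect with bromo at this carbon.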